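The source may hold more compounds than are shown below. What is called first, only, known or untested is meant among the compounds shown, and "the series" means these compounds.

Compound 1, `NC(=O)/C=C1\CCc2c(F)cccc21`: 63%
Compound 2, `NC(=O)/C=C1\CCc2c(F)cc(F)cc21`: 67%

In a functional assay on the whole organism with Mus musculus as the target, at a dose of 100 mg/kg by the intraperitoneal route (a lower number here means less inhibition, a higher number more inhibition at the dose given (going by the name of the read-out)), compound 2 and compound 1 sit within the scatter of each other, as the step of a number 4 percentage points higher from compound 1 to compound 2 (within the scatter) shows, so their numbers are level. Compound 3, `O=C(/C=C1\CCc2c(F)cc(F)cc21)NCCO`, differs from compound 2 by 2-hydroxyethyl in place of hydrogen on an amide-type nitrogen. Among the measured compounds shown here, the only measured step swaps a hydrogen for a fluorine on an aromatic carbon and says nothing about a change on the amide nitrogen, so no measured step bears on this one. Lacking such guidance, the step of a number 12 percentage points lower from compound 2 to compound 3 (beyond the scatter) is expected to be modest, with a wide range. Compound 3 is estimated at 55%, within 25% to 80%.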

Compound 3, a percentage reported as inhibition, in the whole organism at one dose (the size of the read-out at that dose, not a potency): 83%
Beside the measured number, compound 3's estimate is 28 percentage points below it, outside the stated range (above it).
By their numbers in this assay, from the lowest: compounds 1 and 2 (each within the scatter of the next); then compound 3.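

On the amide nitrogen, a substituent can move the result in this assay: 2-hydroxyethyl in place of hydrogen gives a number 16 percentage points higher from compound 2 to compound 3 (beyond the scatter) and so clears the scatter, which the earlier fluoro change on the aromatic carbon did not. The amide nitrogen therefore carries this chain with no loss of inhibition at this dose. No evidence here accounts for the gain.

Still open, as far as these compounds go, is whether the gain needs the hydroxyl or only the chain. A plain ethyl group, a longer hydroxypropyl chain, or an amine or carboxylic acid at the chain end would help separate these.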